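The source may hold more compounds than are shown below. What is called first, only, known or untested is meant among the compounds shown, and "the series" means these compounds.

Two of the compounds in this set have been tested in an in vitro functional assay on cells for agonist activity at Bombesin receptor subtype-3 (Homo sapiens), read by luminescence and calcium flux; a higher number here means that more compound is needed for the effect, a lower number that less compound is needed. Compound 1 `CCCCc1cnc(Cc2ccc(-c3ccccc3C(=O)O)cc2)[nH]1` gives in this assay only a limit, > 10000 nM, and not a number. Compound 2 `N#Cc1cccc(Cc2cnc(CCc3ccc(-c4ccccc4C(=O)O)cc3)[nH]2)c1` gives in this assay 812 nM. Within the data shown here, this is the only full number in the set, since the other value shown is a limit (the limit of > 10000 nM in this assay, at which 1 of the 2 values shown sits), so compound 2 cannot be ranked against a second number; its value simply stands as the one reference point.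

Compound 3 `O=C(O)c1ccccc1-c1ccc(CCc2ncc(Cc3cccc(Cl)c3)[nH]2)cc1` has not yet been measured in this assay. It differs from compound 2 in a single place: chloro in place of cyano on an aromatic carbon. Among the measured compounds shown here, no step between two measured compounds is available to show what such a swap does, so the expectation rests on compound 2 alone. The expected step here is a 1.2-fold lower number from compound 2 to compound 3 (0.06 log units; within the scatter), a small one that may well lie within the usual scatter, with no clear direction either way. Compound 3 is therefore estimated to give 700 nM in this assay, with a plausible range from 200 nM to 2500 nM.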

Compound 3, half-maximal effective concentration: 825 nM
Estimate against measurement, compound 3: 1.2-fold (0.07 log units) below; the measured number falls inside the stated range.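

In this assay, putting chloro in place of cyano on this aromatic carbon gives a 1.0-fold higher number from compound 2 to compound 3 (0.01 log units; within the scatter), so the 3-cyanobenzyl and 3-chlorobenzyl compounds cannot be told apart here. Among these compounds, this is the first step between two measured compounds in the set, and it shows that this position can take either group without a change beyond the scatter, even though the swap replaces 2 heavy atoms with 1 and removes the hydrogen-bond acceptor counted on the cyano. No measured property shown here bears on why the two groups give matching numbers.

Only these two groups are shown at this position, so it remains open whether a methoxy group, a fluorine atom or an amine there would leave the number in place or shift it. As far as these compounds go, this is also a single pair, so it remains open whether the same swap would give a matching result at another place on the ring or on a different core.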